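A few compounds are considered here, and "the series" means these few. Any claim that something is new, unique, unknown or untested is made for them only; others in the source may bear on it.

The study examined three measured compounds and one still awaiting measurement in a functional assay on a cell-free system (plasma) for inhibition of thromboxane A2 receptor (Homo sapiens), read by turbidimetry; a higher number here means a weaker inhibitor, a lower number a stronger inhibitor. Compound 1, `O=C(O)COCCCC[C@H]1[C@H](F)CC[C@@H]1NS(=O)(=O)c1ccc(F)cc1`, gives 1800 nM in this assay. Compound 2, `O=C(O)CCCCCC[C@H]1[C@H](F)CC[C@@H]1NS(=O)(=O)c1ccc(F)cc1`, gives 2400 nM in this assay. The two differ by a single change, (2-carboxyethyl in place of carboxymethoxy on a saturated chain carbon, four bonds along the chain from a saturated ring carbon), and the measured step is a 1.3-fold higher number from compound 1 to compound 2 (0.12 log units; within the scatter). Compound 3, `O=C(O)COCCCC[C@@H]1[C@@H](CNS(=O)(=O)c2ccc(F)cc2)CC[C@H]1F`, gives 650 nM in this assay, the lowest of the three numbers; its gaps to compound 1 and to compound 2 both stand beyond the scatter. The difference between the core of compound 3 and the core of compound 1 is not broken down here. Compound 4, `O=C(O)CCCCCC[C@@H]1[C@@H](CNS(=O)(=O)c2ccc(F)cc2)CC[C@H]1F`, has not yet been measured in this assay. Among the measured compounds shown here, it differs from compound 3 by 2-carboxyethyl in place of carboxymethoxy on a saturated chain carbon, four bonds along the chain from a saturated ring carbon, the same change as the one separating compound 1 and compound 2, made at the same place. That change has appeared only once among the measured pairs, and there it produced a step within the scatter. Because a 1.3-fold higher number from compound 1 to compound 2 (0.12 log units; within the scatter) was so small, the estimated step is a 1.3-fold higher number from compound 3 to compound 4 (0.12 log units; within the scatter), again within the scatter. Compound 4 is therefore expected to give about 850 nM in this assay, most likely between 450 nM and 1700 nM. Whether the change behaves the same way on the core of compound 3 as on the core of compound 1 cannot be told from one earlier instance, so the range is kept fairly wide.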

Compound 4, half-maximal inhibitory concentration: 6000 nM
Compound 4: middle estimate off by 7.1-fold (0.85 log units), on the low side, outside the stated range (above it).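

In this assay, exchanging carboxymethoxy for 2-carboxyethyl on the core of compound 3 gives a 9.2-fold higher number from compound 3 to compound 4 (0.97 log units; beyond the scatter), so on this core the change costs measurable inhibition, and the step is beyond the scatter. Set beside the earlier instance, the same change at the same place did not carry over in size from the core of compound 1 to the core of compound 3: the same change on two cores in this assay, a 1.3-fold higher number (0.12 log units; within the scatter) from compound 1 to compound 2 and a 9.2-fold higher number (0.97 log units; beyond the scatter) from compound 3 to compound 4, 6.9-fold (0.84 log units) apart, beyond the scatter of two such steps. Among the compounds shown here, this shows that, in this series, the size of the step depends on the core it is made on, but with only two cores it does not show which feature of the cores is responsible, why the two steps differ, or what the change would do on a third core.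

The compounds shown leave open how the chain would behave with a sulfur atom or an amine nitrogen in place of the ether oxygen of carboxymethoxy, and whether a longer or shorter chain would show the same difference between the two cores. They also leave open whether an amide in place of the carboxylic acid would follow the same pattern on each core.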